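The compounds below may be only part of what the source reports. "The series", "measured", "known", "first", "only" and "open" are said of these compounds alone.

Measured compounds:

Compound 1, `COc1ccc(-c2nc3cc(C(C)=O)ccc3[nH]2)c(OC)c1OC`: in an ADME assay on MDBK cells (Bos taurus) for cytotoxicity, read by MTT assay, with a stated time of 96 h (a higher number here means that more compound is tolerated, a lower number that less compound is tolerated), compound 1 gives > 100000 nM, which is a limit of the assay rather than a number.
Compound 2, `O=C(CCl)Nc1ccc(-c2nc3cc(C(F)(F)F)ccc3[nH]2)cc1`: in this assay compound 2 gives 17000 nM.
Compound 3, `COc1cc(OC)cc(-c2nc3cc(C(F)(F)F)ccc3[nH]2)c1`: in this assay compound 3 gives > 100000 nM, again a limit rather than a number.

The three compounds share one core and differ in the groups attached to it. Compound 2 is the only one of the three to yield an actual number. Compound 3 stands at the limit of > 100000 nM in this assay, at which 2 of the 3 values shown sit; its result says only that the cells tolerated it up to the edge of what the assay tests, without fixing a value.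

Compound 4, `COc1cccc(-c2nc3cc(C(F)(F)F)ccc3[nH]2)c1`, is the next compound in line. It differs from compound 3 in one place: hydrogen in place of methoxy on an aromatic carbon.

For the measured compounds named here, no pair of measured compounds differs in only one place, so there is no measured step from which to read the size of this change. The change itself is small, a methoxy group dropping to a hydrogen. The expected step of an at least 1.2-fold lower number from compound 3 to compound 4 (0.09 log units; that floor lies within the scatter) is therefore small, within the usual scatter, or at most a modest move toward less tolerance. Compound 4 is estimated to sit near 80000 nM, with a range from 20000 nM to 200000 nM.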

Compound 4, half-maximal cytotoxic concentration: 28000 nM
Estimate against measurement, compound 4: 2.9-fold (0.46 log units) above, and the stated range covers the measured number.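

In this assay, for the compounds shown here, the swap of one methoxy group for hydrogen on an aromatic carbon gives the first step that can be read: it is an at least 3.5-fold lower number from compound 3 to compound 4 (0.55 log units; beyond the scatter) and so lies beyond the usual scatter, which means that even this small change at this place can alter how much compound the cells tolerate. Compound 4 gives 28000 nM as a real number, so this member of the series, with one methoxy group left on the ring, has a measured edge of tolerance that can serve as a reference for later changes. Compound 3 itself stands at a limit and not at a number, and the step is therefore only a lower bound on the true change, because the upper end of the comparison is fixed by the assay and not by the compound: the limit of > 100000 nM in this assay, at which 2 of the 4 values shown sit.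

The compounds shown leave open whether the remaining methoxy group matters in the same way, and what a ring with no methoxy group at all would give. They also leave open how an amine, a hydroxyl group or a fluorine at the same place would compare with the hydrogen of compound 4.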